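Fluoroethoxy to methoxy on the chloropyridine: compound 3

The source may report more compounds than this note shows. Statements on the series, on what has been measured and on what is new or still open speak of the compounds shown alone.

compound 1 `COc1cc(NC(=O)NNc2cc(-c3ccccc3)c3cnn(C)c3n2)cc(Cl)n1` — 3640 nM
compound 2 `Cn1ncc2c(-c3ccc(F)cc3)cc(NNC(=O)Nc3cc(Cl)nc(OCCF)c3)nc21` — 2790 nM

In an assay on isolated protein for binding affinity to sphingosine 1-phosphate receptor 2 (Homo sapiens), read by surface plasmon resonance (on this read-out higher numbers stand for weaker binding and lower numbers for tighter binding), compound 2 gives 2790 nM, the lower of the two numbers, yet its gap to compound 1 at 3640 nM lies within the scatter, so no order between them is claimed. Compound 3 `COc1cc(NC(=O)NNc2cc(-c3ccc(F)cc3)c3cnn(C)c3n2)cc(Cl)n1` is not yet measured. It differs from compound 2 by hydrogen in place of fluoromethyl on a saturated chain carbon bound to an oxygen on an aromatic ring. Among the measured compounds shown here, no measured pair shows this change on its own, so its size in this assay cannot be read from the numbers; nothing beyond the scatter is expected in either direction. Compound 3 is therefore expected near 3100 nM, within 1400 nM to 7000 nM. The expected step is a 1.1-fold higher number from compound 2 to compound 3 (0.05 log units; within the scatter).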

Compound 3, dissociation constant: 1650 nM
Compound 3: the middle estimate sits 1.9-fold (0.27 log units) above what was measured, within the range that was stated.
By their numbers in this assay, from the lowest: compounds 3, 2 and 1 (each within the scatter of the next, the first and the last beyond it).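

In this assay the change from 2-fluoroethoxy to methoxy gives a 1.7-fold lower number from compound 2 to compound 3 (0.23 log units; within the scatter) and stays within the scatter, so the numbers show no clear effect of removing fluoromethyl at this place. Among the compounds shown here, the only step beyond the scatter is fluoro in place of hydrogen on an aromatic carbon, with a 2.2-fold lower number from compound 1 to compound 3 (0.34 log units; beyond the scatter) in the methoxy compounds. Nothing available explains either step.

Still open, on these data alone, is how a longer chain or a terminal amine would read on this saturated chain carbon. As far as these compounds go, whether the fluoro step also holds with 2-fluoroethoxy remains unknown.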